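This account rests on a few compounds, and the source may have more. Where it says the series, first, only, none or still open, it means among the compounds named here.

In a functional assay on MCF7 cells (Homo sapiens) for cytotoxicity, read by MTT assay, with a stated time of 48 h (a higher number here means a weaker inhibitor, a lower number a stronger inhibitor), compound 3 `COc1cc(-n2c(-c3ccc([N+](=O)[O-])cc3)cn(C(C)=O)c2=O)cc(OC)c1OC` is known only as the limit > 50000 nM and not as a number. Compound 2 `COc1cc(-n2c(-c3ccccc3)cn(C(C)=O)c2=O)cc(OC)c1OC` likewise stops at the limit > 50000 nM in this assay and gives no number. For compound 1 `COc1ccc(-c2c[nH]c(=O)n2-c2cc(OC)c(OC)c(OC)c2)cc1OC` the entry in this assay reads "not determined" (no result reported) and so offers no comparison.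

Compound 4 `COc1ccc(-c2cn(C(C)=O)c(=O)n2-c2cc(OC)c(OC)c(OC)c2)cc1OC` follows from compound 3 by this change: 3,4-dimethoxyphenyl in place of 4-nitrophenyl on an aromatic carbon with 3,4-dimethoxyphenyl in place of 4-nitrophenyl on an aromatic carbon, two ring bonds from the ring atom that bears an acetyl group.

Among the measured compounds shown here, the only measured step is a step that the two limits leave unreadable from compound 2 to compound 3 and it has no readable size, and the series so far offers only the limit of > 50000 nM in this assay, at which 2 of the 3 values shown sit, as evidence. No measured size can be carried over to this change, so any expectation in this assay is weak. The expected step of an at least 1.4-fold lower number from compound 3 to compound 4 (0.15 log units; that floor lies within the scatter) is small and leans toward stronger inhibition, and a second limit remains more likely than a number. The estimated value for compound 4 is 35000 nM (expected range 5000 nM to 60000 nM).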

Compound 4, half-maximal inhibitory concentration: > 50000 nM
Compound 4: a limit, no number; the forecaster's own chance of this, stated with the estimate: 55%; middle value at least 1.4-fold (0.15 log units) away from the limit.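

Among the compounds shown here, no step among compound 2, compound 3 and compound 4 can be read in this assay, as none of the three has a number: the limit of > 50000 nM in this assay, at which 3 of the 4 values shown sit. The compounds shown leave open how phenyl, 4-nitrophenyl and 3,4-dimethoxyphenyl on the shared core rank against one another.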